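From pyridin-3-yl to pyridin-4-yl on compound 2

A few compounds are considered here, and "the series" means these few. Any claim that something is new, unique, unknown or untested is made for them only; others in the source may bear on it.

In a functional assay on A549 cells (Homo sapiens) for inhibition, read by MTT assay, with a stated time of 48 h (on this read-out lower numbers stand for stronger inhibition of growth and higher numbers for weaker inhibition of growth), compound 1 `Cn1cc(C2CC(c3ccc(Cl)cc3)=NN2C(=O)c2cccnc2)c2cc(Br)ccc21` gives 7650 nM and compound 2 `COc1ccc(C2=NN(C(=O)c3cccnc3)C(c3cn(C)c4ccc(Br)cc34)C2)cc1OC` gives 2380 nM, the lower of these two numbers. Compound 3 `COc1ccc(C2=NN(C(=O)c3ccncc3)C(c3cn(C)c4ccc(Br)cc34)C2)cc1OC` has the same atoms as compound 2, joined differently: pyridin-4-yl in place of pyridin-3-yl on a carbonyl carbon. The swap is pyridin-4-yl in place of pyridin-3-yl on a carbonyl carbon. For the measured compounds named here, only one measured step exists, a 3.2-fold lower number from compound 1 to compound 2 (0.51 log units; beyond the scatter), and it goes with 3,4-dimethoxyphenyl replacing 4-chlorophenyl, elsewhere in the molecule. Going by the values given here, that step therefore says little about the new change, and no measured pair shows how the pyridine groups compare. With no evidence for a direction, no shift beyond the usual scatter is expected in this assay, though the uncertainty is wide. The expected change is an estimated 1.1-fold higher number from compound 2 to compound 3 (0.02 log units; within the scatter). For compound 3 the estimate is 2500 nM, with an expected range of 1000 nM to 5800 nM.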

Compound 3, concentration for 50% growth inhibition: 4250 nM
Beside the measured number, compound 3's estimate is 1.7-fold (0.23 log units) below it, and the stated range covers the measured number.
By their numbers in this assay, from the lowest: compounds 2, 3 and 1 (each within the scatter of the next, the first and the last beyond it).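

For the compounds shown here, this is the first measured comparison at the group on the carbonyl carbon. In this assay the swap from pyridin-3-yl to pyridin-4-yl gives a 1.8-fold higher number from compound 2 to compound 3 (0.25 log units; within the scatter) and so does not separate the two groups on this read-out, which means that compound 2 and compound 3 count as equal here, and a 3.2-fold lower number from compound 1 to compound 2 (0.51 log units; beyond the scatter) remains the only step shown to lie beyond the scatter. Nothing available explains why the swap leaves the result within the scatter.

The compounds shown leave open whether a pyridine is needed on the carbonyl carbon at all, and a plain phenyl ring, pyridin-2-yl or an open-chain amine there would test this. They also leave open whether the two pyridine groups would still match with 4-chlorophenyl in place of 3,4-dimethoxyphenyl.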